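Urea series: 3-methylphenyl replacing 2-fluorophenyl on the urea nitrogen

A few compounds are considered here, and "the series" means these few. Any claim that something is new, unique, unknown or untested is made for them only; others in the source may bear on it.

Compound 3 `O=C(Nc1cccc(CNc2nccnc2Cl)c1)Nc1ccccc1F` gives 6440 nM in a functional assay on MGC-803 cells (Homo sapiens) for antiproliferative activity, read by MTT assay, with a stated time of 48 h (a lower number here means a stronger inhibitor, a higher number a weaker inhibitor), the lowest of the three numbers. Compound 1 `Cc1ccc(NC(=O)Nc2cccc(CNc3nccnc3Cl)c2)cc1C` gives 9870 nM, compound 2 `O=C(Nc1ccccc1)Nc1cccc(CNc2nccnc2Cl)c1` gives 16300 nM; a 1.5-fold lower number from compound 1 to compound 3 (0.19 log units; within the scatter) stays within the scatter, whereas a 2.5-fold lower number from compound 2 to compound 3 (0.40 log units; beyond the scatter) is modest but beyond it. Compound 4 `Cc1cccc(NC(=O)Nc2cccc(CNc3nccnc3Cl)c2)c1` differs from compound 3 by 3-methylphenyl in place of 2-fluorophenyl on an amide-type nitrogen. The relevant comparisons are a 1.7-fold higher number from compound 1 to compound 2 (0.22 log units; within the scatter), within the scatter, and a 2.5-fold lower number from compound 2 to compound 3 (0.40 log units; beyond the scatter); methyl-bearing and unsubstituted phenyl groups here sit close to each other and somewhat above compound 3. A small rise in the number is therefore expected for compound 4, a 1.7-fold higher number from compound 3 to compound 4 (0.23 log units; within the scatter), possibly within the scatter. Compound 4 is estimated at 11000 nM, with a range of 5000 nM to 22000 nM.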

Compound 4, half-maximal inhibitory concentration: 14600 nM
For compound 4 the middle estimate is 1.3-fold (0.12 log units) below the measured one, and the stated range covers the measured number.
By their numbers in this assay, from the lowest: compounds 3, 1, 4 and 2 (each within the scatter of the next, the first and the last beyond it).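

In this assay, a 2.3-fold higher number from compound 3 to compound 4 (0.36 log units; beyond the scatter) shows that 2-fluorophenyl also separates from 3-methylphenyl, not only from phenyl. A single methyl on the phenyl gives no readable shift, with a 1.1-fold lower number from compound 2 to compound 4 (0.05 log units; within the scatter) and, on the other side, a 1.5-fold higher number from compound 1 to compound 4 (0.17 log units; within the scatter) for the loss of one methyl from 3,4-dimethylphenyl. No measured evidence bears on the separation of compound 3 from compound 4.

Open, as far as these compounds go, is whether this separation follows the fluoro group or its place on the ring, which 2-methylphenyl or 3-fluorophenyl would test. Also open, from the compounds shown here alone, is how a methoxy group or a carboxylic acid on this phenyl would read.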